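A few compounds are considered here, and "the series" means these few. Any claim that something is new, unique, unknown or untested is made for them only; others in the source may bear on it.

In a functional assay on the whole organism with Mus musculus as the target (a higher number here means that more compound is needed for the effect, a lower number that less compound is needed), three compounds built on a shared core have been measured so far. Compound 1 `O=C1CC[C@@H](NC(=O)OCc2ccccc2)C(=O)N1` gives 56.3 mg/kg, compound 2 `CN1C(=O)CC[C@@H](NC(=O)OCc2ccccc2)C1=O` gives 47.5 mg/kg, and compound 3 `O=C1CC[C@H](NC(=O)OCc2ccccc2)C(=O)N1` gives 43.1 mg/kg. All three numbers lie within the usual scatter of one another, so compound 3 does not stand apart from the other two. The measured step of a 1.3-fold lower number from compound 1 to compound 3 (0.12 log units; within the scatter) rests on (the fact that compounds 1 and 3 differ only in the configuration as drawn), and it shows that the configuration as drawn makes no difference beyond the scatter in this small set.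

The next compound is compound 4 `CN1C(=O)CC[C@H](NC(=O)OCc2ccccc2)C1=O`, which carries methyl in place of hydrogen on an amide-type nitrogen in a ring. The same replacement has been measured once, in the opposite configuration, as the step of a 1.2-fold lower number from compound 1 to compound 2 (0.07 log units; within the scatter). For the measured compounds named here, this is the only direct guide, and a single step within the scatter is thin evidence. Even so, it gives no reason to expect a real shift in this assay, so no change beyond the scatter is expected here. The expected step is a 1.1-fold lower number from compound 3 to compound 4 (0.04 log units; within the scatter). For compound 4 the estimated value is 39 mg/kg, with an expected range from 25 mg/kg to 61 mg/kg.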

Compound 4, dose for half-maximal effect: 36.1 mg/kg
Compound 4: the middle estimate sits 1.1-fold (0.03 log units) above what was measured; the measured number falls inside the stated range.
By their numbers in this assay, from the lowest: compounds 4, 3, 2 and 1 (each within the scatter of the next).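

The methyl in place of the amide hydrogen can now be read in both configurations as drawn, and a 1.2-fold lower number from compound 3 to compound 4 (0.08 log units; within the scatter) closely matches the step seen in the other configuration, so in this assay this change on an amide-type nitrogen in a ring has the same small size on both cores: the same change on two cores in this assay, a 1.2-fold lower number (0.07 log units; within the scatter) from compound 1 to compound 2 and a 1.2-fold lower number (0.08 log units; within the scatter) from compound 3 to compound 4, 1.0-fold (0.00 log units) apart, within the scatter of two such steps

The configuration can now also be read with the methyl in place, and a 1.3-fold lower number from compound 2 to compound 4 (0.12 log units; within the scatter) shows that it makes no difference beyond the scatter there, just as it made none with the hydrogen in place: the fact that compounds 2 and 4 differ only in the configuration as drawn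

Across these four compounds, the size of each change therefore does not depend on the other, and neither change moves the number beyond the scatter.

The compounds shown leave open whether anything larger than methyl on this nitrogen, such as an ethyl group, a longer chain or a chain ending in an amine, would shift the number beyond the scatter. From the compounds shown here alone, the large group on the ring is also the same in all four compounds, so what a change there would do remains unknown.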